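A few compounds are considered here, and "the series" means these few. Any claim that something is new, unique, unknown or untested is made for them only; others in the source may bear on it.

Measured in an ADME assay on Raji cells (Homo sapiens) for cytotoxicity, with a stated time of 72 h (on this read-out higher numbers stand for an effect only at larger amounts of compound and lower numbers for an effect already at smaller amounts), so far:
compound 1 `Cc1cc(NC(=O)Nc2cccc(C(N)=O)c2)c2ccccc2n1` gives > 25000 nM as a limit of the assay
compound 2 `Cc1cc(NC(=O)Nc2ccc(N(C)C)cc2)c2ccccc2n1` gives > 25000 nM as a limit of the assay

Compound 2 has no number to stand on: in this assay compound 2 gives > 25000 nM and this is a limit, not a number. Within the data shown here, the series so far comes down to the limit of > 25000 nM in this assay, at which 2 of the 2 values shown sit, and no order can be drawn among the measured compounds.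

Compound 3 `Cc1cc(NC(=O)Nc2ccc(SC(F)(F)F)cc2)c2ccccc2n1` takes (trifluoromethyl)sulfanyl in place of dimethylamino on an aromatic carbon, para to a large group, and the counted change is (trifluoromethyl)sulfanyl in place of dimethylamino on an aromatic carbon here.

Among the measured compounds shown here, no measured step gives a size for such a change. The expectation rests only on the structural change and on compound 2 with its limit of > 25000 nM in hand. Expected is either no shift beyond the scatter or a modest move toward lower numbers in this assay and another limit is somewhat more likely than a number. The expected at least 1.6-fold lower number from compound 2 to compound 3 (0.22 log units; that floor lies within the scatter) is therefore small. For compound 3 the estimate is 15000 nM with an expected range from 5000 nM to 25000 nM as its ends.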

Compound 3, half-maximal effective concentration: 10000 nM
Estimate against measurement, compound 3: 1.5-fold (0.18 log units) above; the range from low to high includes it.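

In this assay, among these compounds, the aromatic carbon para to a large group is the first place where a single change is seen to move the read-out: (trifluoromethyl)sulfanyl in place of dimethylamino gives an at least 2.5-fold lower number from compound 2 to compound 3 (0.39 log units; beyond the scatter). Among the compounds shown here, compound 3 also provides the first value that is a number rather than a limit, 10000 nM, so an order can now be drawn for this one pair. The step remains a floor and not a full size because one of its ends rests on a limit: the limit of > 25000 nM in this assay, at which 2 of the 3 values shown sit.

On these data alone, one pair cannot separate what the loss of dimethylamino contributes from what the arrival of (trifluoromethyl)sulfanyl contributes, and the true distance between compound 2 and compound 3 remains unknown. Groups such as methoxy, chlorine or trifluoromethyl on the same aromatic carbon would be needed to show whether the shift belongs specifically to (trifluoromethyl)sulfanyl or is shared more widely at this position.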